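Compound 3 to compound 4: a biaryl swap at the assay limit

A few compounds are considered here, and "the series" means these few. Any claim that something is new, unique, unknown or untested is made for them only; others in the source may bear on it.

In an ADME assay on MRC5 cells (Homo sapiens) for cytotoxicity, read by fluorescence, with a stated time of 72 h (on this read-out lower numbers stand for stronger inhibition and higher numbers for weaker inhibition), compound 1 (`CC1(COc2ccc(OC(F)(F)F)cc2)Cn2cc([N+](=O)[O-])nc2O1`) gives > 64000 nM, which is a limit and not a number. Compound 2 (`CC1(COc2ccc(F)cc2)Cn2cc([N+](=O)[O-])nc2O1`) gives > 64000 nM, also a limit. Compound 3 (`CC1(COc2ccc(Oc3ccccc3)cc2)Cn2cc([N+](=O)[O-])nc2O1`) gives > 64000 nM, again a limit, so it has no exact position in the series. Among the measured compounds shown here, the whole set therefore stands at the limit of > 64000 nM in this assay, at which 3 of the 3 values shown sit, and no measured compound goes against this.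

Compound 4 (`CC1(COc2ccc(-c3ccc(C(F)(F)F)cc3)cc2)Cn2cc([N+](=O)[O-])nc2O1`) has 4-(trifluoromethyl)phenyl in place of phenoxy on an aromatic carbon, para to a large group: 4-(trifluoromethyl)phenyl in place of phenoxy on an aromatic carbon.

All three measured steps bear on this change, though none gives a size. The closest is a step that the two limits leave unreadable from compound 2 to compound 3, which changes the group on the same kind of aromatic carbon. The other two are a step that the two limits leave unreadable from compound 1 to compound 2 and a step that the two limits leave unreadable from compound 1 to compound 3. Since these steps offer no size to carry over, no readable shift in this assay is expected, in either direction. The estimated step is an at least 1.0-fold lower number from compound 3 to compound 4 (0.02 log units; that floor lies within the scatter), and a further limit reading is the most likely result.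

For compound 4 the estimated value is 60000 nM, with an expected range from 25000 nM to 64000 nM.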

Compound 4, half-maximal inhibitory concentration: > 64000 nM
Compound 4 ended at the assay's limit (the forecaster's own chance of this, stated with the estimate: 75%); at least 1.0-fold (0.02 log units) between middle value and limit.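

In this assay compound 4 gives > 64000 nM, which is a limit. The steps to compound 4 from compound 1, compound 2 and compound 3 therefore cannot be read. The compounds shown leave open whether any of the four differs from the others in this read-out, since all stand at one limit: the limit of > 64000 nM in this assay, at which 4 of the 4 values shown sit.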